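The compounds below may be only part of what the source reports. "The series", "measured", "known", "first", "only" and "open" are said of these compounds alone.

Three ureas on the shared core of compound 1 `Cc1cccc(C)c1NC(=O)Nc1ccncc1` have been run in a functional assay on the whole organism with Mus musculus as the target, in the maximal electroshock model, with a stated time of 30 min; on this read-out lower numbers stand for an effect already at smaller amounts and higher numbers for an effect only at larger amounts of compound. Compound 1 gives 30 mg/kg. Compound 2 `O=C(Nc1ccncc1)Nc1ccccc1F` gives 100 mg/kg in this assay. Compound 3 `N#Cc1ccccc1NC(=O)Nc1ccncc1` returns only a limit of the assay, > 300 mg/kg, and not a number. Among the compounds with values here, compound 3 is thus the one compound that sits at the limit of > 300 mg/kg in this assay, at which 1 of the 3 values shown sits. Within the data shown here, the single measured change at this ring carbon, an at least 3.0-fold higher number from compound 2 to compound 3 (0.47 log units; beyond the scatter), therefore tells only that the number rose by that amount or more.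

Compound 4 `O=C(Nc1ccncc1)Nc1ccccc1O` differs from compound 3 by hydroxy in place of cyano on an aromatic carbon. Among the measured compounds shown here, no measured step involves a hydroxy group, so the step from compound 2 to compound 3 is the only one that bears on this change, and it bears only loosely, since it concerns the group that leaves rather than the one that enters. Compound 2 gives a measurable 100 mg/kg and compound 1 a measurable 30 mg/kg. Compound 3, by contrast, reaches the limit of the assay. The expected step for compound 4 is an at least 1.5-fold lower number from compound 3 to compound 4 (0.17 log units; that floor lies within the scatter), a return toward measurable numbers, though a second limit remains possible. Compound 4 is estimated at 200 mg/kg, between 70 mg/kg and 600 mg/kg.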

Compound 4, minimum effective dose: > 300 mg/kg
Compound 4 gave a limit, no number; the forecaster's own chance of this, stated with the estimate: 35%; middle value at least 1.5-fold (0.17 log units) away from the limit.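

Hydroxy in place of fluoro on this aromatic carbon gives an at least 3.0-fold higher number from compound 2 to compound 4 (0.47 log units; beyond the scatter), so cyano is no longer the only group shown at this carbon with a step of this direction from compound 2 in this assay. The step between compound 3 and compound 4 cannot be read, since both ends are limits of the assay and not numbers. Cyano, with no hydrogen-bond donor, and hydroxy, with one, therefore end at the same place, and a hydrogen-bond donor at this carbon does not restore a measurable number in compound 4: the limit of > 300 mg/kg in this assay, at which 2 of the 4 values shown sit.

No order between cyano and hydroxy can be given from these compounds. Going by these compounds, whether an amine or a methoxy group on this carbon would return a measurable number, as fluoro does in compound 2, stays open.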